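Working notes: hydroxy to hydrogen on the shared core

A few compounds are considered here, and "the series" means these few. Any claim that something is new, unique, unknown or untested is made for them only; others in the source may bear on it.

Measured so far:
Compound 1, `COc1ccc2[nH]c(-c3ccc(C)[se]3)cc(=O)c2c1OC`: in a functional assay on Hep 3B2 cells (Homo sapiens) for cytotoxicity, read by MTT assay, with a stated time of 48 h (on this read-out lower numbers stand for stronger inhibition and higher numbers for weaker inhibition), compound 1 reaches only the assay limit, > 50000 nM.
Compound 2, `COc1ccc2[nH]c(-c3ccc(C)[se]3)cc(=O)c2c1O`: in this assay compound 2 gives 800 nM.

Going by the values given here, compound 2 holds the only numerical value in this assay; the other result is a limit, see (the limit of > 50000 nM in this assay, at which 1 of the 2 values shown sits). Among the compounds with values here, the single measured step, an at least 62-fold lower number from compound 1 to compound 2 (1.79 log units; beyond the scatter), was large, and it came from exchanging a methyl for hydrogen on the oxygen of the shared core. Compound 3, `COc1ccc2[nH]c(-c3ccc(C)[se]3)cc(=O)c2c1`, is not yet measured; it differs from compound 2 by hydrogen in place of hydroxy on an aromatic carbon. Within the data shown here, no measured step removes the oxygen outright, so the step from compound 1 to compound 2 bears on it only indirectly: it shows that this spot on the core is sensitive, with a large difference between hydroxy and methoxy. Removing the hydroxy entirely is a different change, and the direction can only be inferred from that sensitivity. A loss beyond the scatter is expected for compound 3, a 13-fold higher number from compound 2 to compound 3 (1.10 log units; beyond the scatter). The estimate for compound 3 in this assay is 10000 nM, with a range of 1500 nM to 50000 nM.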

Compound 3, half-maximal inhibitory concentration: 3000 nM
Compound 3: middle estimate off by 3.3-fold (0.52 log units), on the high side, within the range that was stated.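

In this assay, taking the hydroxy off the aromatic carbon of the shared core costs only a modest amount, a 3.8-fold higher number from compound 2 to compound 3 (0.57 log units; beyond the scatter), so the earlier contrast between hydroxy and methoxy cannot be read as a simple need for the hydroxy at this position. Replacing the methoxy with hydrogen at the same carbon gives a large gain, an at least 16-fold lower number from compound 1 to compound 3 (1.22 log units; beyond the scatter), which places hydrogen between the two oxygen groups and shows that, among these three compounds, the methoxy is the poorest choice here, not merely a weaker substitute for the hydroxy. Compound 1 supplies a limit rather than a number, so the size of this second step is open at one end: the limit of > 50000 nM in this assay, at which 1 of the 3 values shown sits.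

The compounds shown leave open how an amine, a fluorine or a longer chain on the oxygen, such as ethoxy, would read at this position in this assay, so the order among hydroxy, hydrogen and methoxy cannot yet be extended to other groups. They also leave open what the methoxy group ortho to this position contributes, since it stays unchanged from compound 2 to compound 3.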